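Chloro added beside the trifluoromethyl group on compound 3

A few compounds are considered here, and "the series" means these few. Any claim that something is new, unique, unknown or untested is made for them only; others in the source may bear on it.

Measured so far in a functional assay on A375P cells (Homo sapiens) for antiproliferative activity, read by MTT assay, with a stated time of 48 h; a lower number here means a stronger inhibitor, a higher number a weaker inhibitor:
- compound 1 `Nc1cccc2c(-c3cccc(NC(=O)c4ccc(Cl)c(C(F)(F)F)c4)c3)ccnc12` gives 1400 nM
- compound 2 `COc1ccc(C(=O)Nc2cccc(-c3ccnc4c(NC(C)=O)cccc34)c2)cc1OC` gives 5300 nM
- compound 3 `CC(=O)Nc1cccc2c(-c3cccc(NC(=O)c4cccc(C(F)(F)F)c4)c3)ccnc12` gives 8000 nM

Compound 3 carries the highest number of the three; its distance to compound 2 lies within the scatter, while compound 1 sits well below it. For the measured compounds named here, the only single-place step in the set, a 1.5-fold higher number from compound 2 to compound 3 (0.18 log units; within the scatter), swaps one aryl amide for another and says nothing directly about a chloro substituent.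

Compound 4 `CC(=O)Nc1cccc2c(-c3cccc(NC(=O)c4ccc(Cl)c(C(F)(F)F)c4)c3)ccnc12` differs from compound 3 in one place: chloro in place of hydrogen on an aromatic carbon. Compound 1 carries this same chloro-bearing aryl group but with a different substituent on the shared core, so the two structures differ in two places and no single step can be read from them; their values only show that the chloro-bearing analogue reaches a clearly lower number.

Taken together, a lowering of the number is expected, of a size that may just pass the scatter, a 2.3-fold lower number from compound 3 to compound 4 (0.36 log units; beyond the scatter). For compound 4 the estimate in this assay is 3500 nM, within a range of 1400 nM to 9000 nM.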

Compound 4, half-maximal inhibitory concentration: 2400 nM
The estimate for compound 4 lay 1.5-fold (0.16 log units) above the measured number; measured number inside the range.
By their numbers in this assay, from the lowest: compounds 1 and 4 (each within the scatter of the next); then compounds 2 and 3 (each within the scatter of the next).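

In this assay, chloro on the aromatic carbon ortho to the trifluoromethyl group gives a step beyond the scatter (a 3.3-fold lower number from compound 3 to compound 4 (0.52 log units; beyond the scatter)), so this position responds to a single added atom. The 4-chloro-3-(trifluoromethyl)phenyl amide also separates from the 3,4-dimethoxyphenyl amide (a 2.2-fold lower number from compound 2 to compound 4 (0.34 log units; beyond the scatter)), whereas the same swap without chloro stayed within the scatter (a 1.5-fold higher number from compound 2 to compound 3 (0.18 log units; within the scatter)). With the chloro-bearing aryl group in place, acetyl in place of hydrogen on the core nitrogen gives a step within the scatter (a 1.7-fold higher number from compound 1 to compound 4 (0.23 log units; within the scatter)), so the two compounds cannot be told apart here.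

Going by these compounds, whether bromo, methyl or methoxy at this position would match chloro remains open. Nothing measured on these compounds explains the chloro step.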